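The source may hold more compounds than are shown below. What is called first, only, known or untested is meant among the compounds shown, and "the series" means these compounds.

Of the compounds shown here, three have so far been measured in a functional assay on MDA-MB-231 cells for antagonist activity at C-X-C chemokine receptor type 4 (Homo sapiens), tested at 100 nM; on this read-out higher numbers stand for a stronger effect at the one concentration tested and lower numbers for a weaker effect. Compound 1 `Fc1cnc(NCc2ccc(CNc3nccc(C(F)(F)F)n3)cc2)nc1` gives 93%, compound 3 `Clc1nc(Cl)nc(NCc2ccc(CNc3nc(Cl)nc(Cl)n3)cc2)n1` gives 82%, and compound 2 `c1ccc(NCc2ccc(CNc3ccccc3)cc2)cc1` gives 64%. Compound 2 therefore stands lowest of the three, beyond the scatter below compound 3 and further still below compound 1. Compound 4 `c1ccc(NCc2ccc(CNc3ncccn3)cc2)cc1` differs from compound 2 in one place: pyrimidin-2-yl in place of phenyl on an amine nitrogen. Among the measured compounds shown here, no measured pair shows this same change, so its size can only be guessed. Since compound 1 gives 93% and compound 3 gives 82%, both above compound 2, a modest upward step is expected for compound 4, although the change touches only one amine nitrogen. The expected step from compound 2 to compound 4 is a number 8 percentage points higher from compound 2 to compound 4 (within the scatter). For compound 4 the estimated value is 72%, within a range from 55% to 88%.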

Compound 4, a percentage reported as inhibition, at one concentration (the size of the read-out at that concentration, not a potency): 100%
Estimate against measurement, compound 4: 28 percentage points below; measured number outside the range, above it.
By their numbers in this assay, from the lowest: compound 2; then compound 3; then compounds 1 and 4 (each within the scatter of the next).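

In this assay, pyrimidin-2-yl in place of phenyl on an amine nitrogen gives a number 36 percentage points higher from compound 2 to compound 4 (beyond the scatter), so a change at this one position, with the rest of the molecule untouched, is enough to produce a large step. The earlier compounds shown here differ from one another in more than one place and could not show this. Nothing measured here accounts for the step. The compounds shown leave open whether a pyridin-2-yl group on the same amine nitrogen would give a similar step. They also leave open whether replacing the remaining phenyl with pyrimidin-2-yl would change the read-out further.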